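Swapping the chain for a benzyl group on a shared core

The source may hold more compounds than are shown below. What is called first, only, known or untested is meant among the compounds shown, and "the series" means these compounds.

Compound 1, `CC(C)CCn1cnc2c(Nc3ccc(Cl)cc3)nc(N[C@H]3CC[C@H](N)CC3)nc21`, gives 1800 nM in a functional assay on K562 cells (Homo sapiens) for inhibition, read by fluorescence, with a stated time of 72 h; a higher number here means a weaker inhibitor of growth, a lower number a stronger inhibitor of growth.
Compound 2, `CC(C)=CCC/C(C)=C/Cn1cnc2c(Nc3cccc(Cl)c3)nc(N[C@H]3CC[C@H](N)CC3)nc21`, gives 2200 nM in this assay.
Compound 3, `CCCCn1cnc2c(Nc3ccccc3)nc(N[C@H]3CC[C@H](N)CC3)nc21`, gives 3200 nM in this assay.

These three share one core and differ in the group on the aromatic nitrogen and in the substituent on the aniline ring. Their numbers in this assay sit close together: compound 2 holds the second highest of the three, with compound 1 nearest to it and compound 3 furthest from it, and both of those gaps fall within the usual scatter of the measurement. Going by the values given here, on these numbers, no compound can be called stronger or weaker than another.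

Compound 4, `N[C@H]1CC[C@H](Nc2nc(Nc3cccc(Cl)c3)c3ncn(Cc4ccccc4)c3n2)CC1`, is the next compound to be measured in this assay. It keeps the aniline ring of compound 2 and changes only the group on the aromatic nitrogen: phenyl in place of 2,6-dimethylhepta-1,5-dien-1-yl on a saturated chain carbon bound to an aromatic nitrogen. In this change a branched chain with two double bonds outside aromatic rings is replaced by one six-membered aromatic ring of carbon only.

Among the compounds with values here, nothing measured so far shows a step from one chain to another that reaches beyond the scatter, so the expected step is a 1.1-fold lower number from compound 2 to compound 4 (0.04 log units; within the scatter), no change beyond the scatter in either direction. Compound 4 is therefore expected to give about 2000 nM, with a range from 700 nM to 6000 nM.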

Compound 4, concentration for 50% growth inhibition: 3000 nM
Compound 4: the middle estimate sits 1.5-fold (0.18 log units) below what was measured; low and high end bracket the measured number.
By their numbers in this assay, from the lowest: compounds 1, 2, 4 and 3 (each within the scatter of the next).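

Going by these compounds alone, this is the first pair in the set that differs in one place only, and in this assay phenyl in place of 2,6-dimethylhepta-1,5-dien-1-yl on a saturated chain carbon bound to an aromatic nitrogen gives a 1.4-fold higher number from compound 2 to compound 4 (0.13 log units; within the scatter), a step that cannot be told apart from repeat-to-repeat variation. With the rest of compound 2 held constant, a branched chain of 9 heavy atoms with two double bonds and no ring can therefore be exchanged for one six-membered aromatic ring of carbon only, without a change in this read-out that can be called real. Nothing measured here accounts for the two groups reading alike.

The compounds shown leave open whether a group at this place carrying an amine or a carboxylic acid, in place of the purely carbon groups seen so far, would give a number beyond the scatter. Compound 1 and compound 3 each differ from compound 2 in two places, so the part played by the chloro substituent on the aniline ring, taken alone, also remains unread.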